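Swapping the Halogenated Ring on Compound 1

The source may hold more compounds than are shown below. What is called first, only, known or untested is meant among the compounds shown, and "the series" means these compounds.

Compound 1 `O=C(CSc1nnc(-c2ccncc2)o1)N/N=C/c1ccc(Br)cc1`: 18600 nM
Compound 2 `O=C(CSc1nnc(-c2ccncc2)o1)N/N=C/c1cc(Br)ccc1O`: 6490 nM
Compound 3 `O=C(CSc1nnc(-c2ccncc2)o1)N/N=C/c1cc(Br)cc(Br)c1O`: 6540 nM

In a functional assay on HepG2 cells (Homo sapiens) for cytotoxicity, read by MTT assay, with a stated time of 48 h (on this read-out higher numbers stand for weaker inhibition and lower numbers for stronger inhibition), compound 1 gives 18600 nM, the highest number of the three measured compounds and therefore the weakest inhibition seen so far. Compound 4 `O=C(CSc1nnc(-c2ccncc2)o1)N/N=C/c1ccc(Cl)cc1Cl` has not yet been tested. It keeps the shared core of compound 1 and differs in one place: 2,4-dichlorophenyl in place of 4-bromophenyl on a carbon with a double bond to nitrogen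

Two measured steps start from compound 1. The step of a 2.9-fold lower number from compound 1 to compound 2 (0.46 log units; beyond the scatter) and the step of a 2.8-fold lower number from compound 1 to compound 3 (0.45 log units; beyond the scatter) each brought in a ring carrying a 2-hydroxyphenyl pattern, which compound 4 does not have. The step of a 1.0-fold higher number from compound 2 to compound 3 (0.00 log units; within the scatter), which only adds a bromo to an aromatic carbon, shows that adding a halogen alone changed little. Since the change to compound 4 only rearranges and exchanges halogens on the ring, the expectation is a step of a 1.2-fold lower number from compound 1 to compound 4 (0.09 log units; within the scatter) that stays near compound 1. Compound 4 is therefore estimated at 15000 nM, with a range from 6000 nM to 40000 nM.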

Compound 4, half-maximal inhibitory concentration: 18600 nM
Beside the measured number, compound 4's estimate is 1.2-fold (0.09 log units) below it, within the range that was stated.
By their numbers in this assay, from the lowest: compounds 2 and 3 (each within the scatter of the next); then compounds 1 and 4 (each within the scatter of the next).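

Exchanging 4-bromophenyl for 2,4-dichlorophenyl on this carbon gives no change at the digits printed from compound 1 to compound 4 (within the scatter) in this assay, so these two halogen-only rings cannot be told apart on this read-out. The step of a 2.8-fold higher number from compound 3 to compound 4 (0.45 log units; beyond the scatter) and the step of a 2.9-fold higher number from compound 2 to compound 4 (0.46 log units; beyond the scatter) both lie beyond the scatter, and among these four compounds the two rings named as 2-hydroxyphenyl give the lower numbers, with no compound going against this. No evidence is available to explain this difference.

From the compounds shown here alone, whether the hydroxy group would give the same result without any bromo on the ring remains open. Also open, going by these compounds, is how a ring carrying an amine or a carboxylic acid would behave at this position.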